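A Methyl Added to the Acetyl Group of Compound 3

The compounds below may be only part of what the source reports. "The series", "measured", "known", "first", "only" and "open" are said of these compounds alone.

In a functional assay on PC-3 cells (Homo sapiens) for antiproliferative activity, read by MTT assay, with a stated time of 72 h (on this read-out higher numbers stand for weaker inhibition and lower numbers for stronger inhibition), compound 1 (`CCOC(=O)c1csc2nc(CN3CCN(Cc4ccccc4)CC3)c(-c3ccc(Br)cc3)n12`) gives 56400 nM while compound 2 (`Cc1ccc(-c2c(CN3CCCCC3)nc3scc(C(=O)O)n23)cc1`) gives 16600 nM and compound 3 (`CC(=O)NNC(=O)c1csc2ncc(-c3ccc(C)cc3)n12`) gives 92700 nM as its measured concentration. Compound 3 stands at the weak end of this small set together with compound 1, the two lying within the scatter of each other, whereas compound 2 gives a lower number, beyond the scatter.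

Compound 4 (`CCC(=O)NNC(=O)c1csc2ncc(-c3ccc(C)cc3)n12`) differs from compound 3 in one place (methyl in place of hydrogen on a saturated chain carbon bound to a carbonyl carbon), with methyl in place of hydrogen on a saturated chain carbon bound to a carbonyl carbon, so that acetyl becomes propanoyl. Within the data shown here, no pair of measured compounds differs in only one place, so the data hold no direct precedent for this change. No step beyond the scatter is expected in this assay in either direction. The estimated change is a 1.2-fold lower number from compound 3 to compound 4 (0.06 log units; within the scatter) and it stays within the scatter. The value expected for compound 4 is 80000 nM with an estimated range from 35000 nM to 180000 nM in this measurement.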

Compound 4, half-maximal inhibitory concentration: 18500 nM
Beside the measured number, compound 4's estimate is 4.3-fold (0.64 log units) above it; measured number outside the range, below it.
By their numbers in this assay, from the lowest: compounds 2 and 4 (each within the scatter of the next); then compounds 1 and 3 (each within the scatter of the next).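

Acetyl to propanoyl is the only one-place change among these compounds, and in this assay it gives a 5.0-fold lower number from compound 3 to compound 4 (0.70 log units; beyond the scatter), with stronger inhibition for compound 4. Among these compounds, this shows that, on this shared core, a single methyl in place of hydrogen on a saturated chain carbon bound to a carbonyl carbon can move the number beyond the scatter, which the earlier compounds, with no one-place pair among them, could not show. Nothing available here bears on why the step has this size.

From the compounds shown here alone, whether a longer chain such as butanoyl, or an amine or a carboxylic acid at this place, would carry the step further, keep it or reverse it remains open. Going by these compounds, with a single pair, it is also open whether the same methyl would give a similar step with other groups on the core.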